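The compounds below may be only part of what the source reports. "The series", "measured", "known", "first", "only" and "open" are said of these compounds alone.

Compound 1 `O=C1CCCCC/C1=C\c1ccccc1`: 261000 nM
Compound 2 `O=C1CCCCC/C1=C\c1ccc(F)cc1`: 291000 nM
Compound 3 `COc1ccc(/C=C2\CCCCCC2=O)cc1`: 306000 nM

In a functional assay on L1210 cells (Mus musculus) for inhibition (a higher number here means a weaker inhibitor, a lower number a stronger inhibitor), compound 1 stands level with the other two measured compounds, as all three values lie within the scatter of one another. Compound 4 `O=C1CCCCC/C1=C\c1cccc([N+](=O)[O-])c1` has not yet been measured. It keeps the core of compound 1 and carries nitro in place of hydrogen on an aromatic carbon. Among the compounds with values here, two measured steps bear most directly on this change, as each also replaces a hydrogen on an aromatic carbon: a 1.1-fold higher number from compound 1 to compound 2 (0.05 log units; within the scatter) and a 1.2-fold higher number from compound 1 to compound 3 (0.07 log units; within the scatter). Exchanging those two groups for each other gives a similarly small step: a 1.1-fold higher number from compound 2 to compound 3 (0.02 log units; within the scatter). Within the data shown here, no measured step involves a nitro group, so these steps are only a rough guide. Even so, no step beyond the scatter is expected in this assay, and no direction can be favoured. The estimate is a 1.0-fold lower number from compound 1 to compound 4 (0.02 log units; within the scatter). Compound 4 is expected at 250000 nM, with an estimated range from 120000 nM to 480000 nM.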

Compound 4, half-maximal inhibitory concentration: 162000 nM
For compound 4 the middle estimate is 1.5-fold (0.19 log units) above the measured one; low and high end bracket the measured number.
By their numbers in this assay, from the lowest: compounds 4, 1, 2 and 3 (each within the scatter of the next).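

Placing nitro on an aromatic carbon, meta to a group of 9 heavy atoms, gives a 1.6-fold lower number from compound 1 to compound 4 (0.21 log units; within the scatter) in this assay. So a substituent of 3 heavy atoms, with 2 hydrogen-bond acceptors, can sit at this place on the ring without a step beyond the scatter, and compound 4 is the first of the compounds shown to carry a group there. No measurement shown explains this result.

On these data alone, it remains open whether an amine or a carboxylic acid on the same aromatic carbon would also stay within the scatter of compound 1. Nor do these compounds show whether nitro would give a similar result at another place on the ring, or whether any change to the shared core would move the number further than these ring substituents have.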